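The source may hold more compounds than are shown below. What is called first, only, known or untested is meant among the compounds shown, and "the series" means these compounds.

Within the data shown here, compound 2, `O=c1ccc2ccc(O)c(CNCc3ccccc3)c2o1`, holds the lowest of the two numbers so far in an assay on isolated protein for inhibition of seed linoleate 13S-lipoxygenase-1 (Glycine max) (a higher number here means a weaker inhibitor, a lower number a stronger inhibitor), where compound 2 gives 44000 nM; its nearest neighbour is compound 1, `CC(C)CNCc1c(O)ccc2ccc(=O)oc12`, which in this assay gives 47000 nM. Among the measured compounds shown here, the one step between them, a 1.1-fold lower number from compound 1 to compound 2 (0.03 log units; within the scatter), shows that phenyl in place of isopropyl on a saturated chain carbon bound to an amine nitrogen changes little here. Compound 3, `CCNCc1c(O)ccc2ccc(=O)oc12`, is reached from compound 2 by methyl in place of phenyl on a saturated chain carbon bound to an amine nitrogen. For the measured compounds named here, only the step from compound 1 to compound 2 bears on this change, and it lay within the scatter, so the expectation for compound 3 in this assay is a step of a 1.1-fold higher number from compound 2 to compound 3 (0.06 log units; within the scatter), that is no movement beyond the scatter, with no direction favoured. On that basis compound 3 is estimated at 50000 nM, with a range from 25000 nM to 100000 nM.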

Compound 3, half-maximal inhibitory concentration: 52000 nM
Compound 3: the middle estimate sits 1.0-fold (0.02 log units) below what was measured; low and high end bracket the measured number.
By their numbers in this assay, from the lowest: compounds 2, 1 and 3 (each within the scatter of the next).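

With compound 3, methyl joins phenyl and isopropyl at this place, on a saturated chain carbon bound to an amine nitrogen, and this assay gives a 1.2-fold higher number from compound 2 to compound 3 (0.07 log units; within the scatter) and a 1.1-fold higher number from compound 1 to compound 3 (0.04 log units; within the scatter). The earlier compounds shown here compared only phenyl with isopropyl, whereas these steps show that, across these three compounds, neither the loss of the aromatic ring nor the change to the single-carbon methyl moves the number beyond the scatter. No supporting evidence is available to explain this result.

The compounds shown leave open whether a longer chain, a carboxylic acid or a hydroxyl at this place would move the number beyond the scatter. They also leave open whether any change to the shared core, rather than to this group, would do so.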